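Swapping morpholine for cyclohexane on an amide nitrogen

The source may hold more compounds than are shown below. What is called first, only, known or untested is meant among the compounds shown, and "the series" means these compounds.

Measured so far:
Compound 1, `CO[C@H]1CC[C@H](NC(=O)c2n[nH]cc2NC(=O)c2ccc(F)cc2F)CC1`, gives 11000 nM in an ADME assay on MRC5 cells (Homo sapiens) for inhibition, with a stated time of 72 h; on this read-out higher numbers stand for an effect only at larger amounts of compound and lower numbers for an effect already at smaller amounts.
Compound 2, `COc1cccc(OC)c1C(=O)Nc1c[nH]nc1C(=O)NN1CCOCC1`, reaches only a limit in this assay, namely > 50000 nM.

Compound 2 therefore sits at the limit of > 50000 nM in this assay, at which 1 of the 2 values shown sits: the read-out stopped at the top of the tested range, so for compound 2 only a floor on its value is known, not a number. Compound 1, the other measured compound, does give a number, and it lies below that limit.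

Compound 3, `COc1cccc(OC)c1C(=O)Nc1c[nH]nc1C(=O)NC1CCCCC1`, is not yet measured. It differs from compound 2 in one place: cyclohexyl in place of morpholin-4-yl on an amide-type nitrogen. Nothing else in the shared core or in the amide on the other side changes.

Among the measured compounds shown here, no step between two measured compounds is known here, so the expected size of the change in this assay rests on the structures alone. The step of an at least 1.6-fold lower number from compound 2 to compound 3 (0.22 log units; that floor lies within the scatter) is expected to be modest and downward, that is, toward an effect at smaller amounts, though it may well stay within the usual scatter or end at the same limit. Compound 3 is therefore estimated to give about 30000 nM in this assay, somewhere between 8000 nM and 60000 nM.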

Compound 3, half-maximal effective concentration: 35000 nM
Beside the measured number, compound 3's estimate is 1.2-fold (0.07 log units) below it, and the stated range covers the measured number.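

Cyclohexyl on this amide-type nitrogen gives a number that can be read in this assay, whereas morpholin-4-yl gave none, so this position now has a first measured value for a ring of carbon only. Swapping a ring with 2 hetero atoms for that carbon ring gives an at least 1.4-fold lower number from compound 2 to compound 3 (0.15 log units; that floor lies within the scatter), so the compounds shown establish no real change at this position, though they do not rule one out either. The true size of the step stays unknown because compound 2 rests at a limit of the read-out, not at a number: the limit of > 50000 nM in this assay, at which 1 of the 3 values shown sits.

Still open, on these data alone, is which part of the morpholin-4-yl group matters, since the ring oxygen and the ring nitrogen leave together in this swap; a piperidin-1-yl group, which keeps that ring nitrogen but has no ring oxygen, would separate the two, and a plain butyl chain would show whether a ring is needed at all. Also open, as far as these compounds go, is whether the same swap would give a similar step with a different amide on the other side of the shared core.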